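This account rests on a few compounds, and the source may have more. Where it says the series, first, only, none or still open, it means among the compounds named here.

Measured compounds:
compound 1, `CCCC[C@@H](C)C[C@@H](C)C(=O)N(C)[C@@H](CC(C)C)C(=O)N[C@H](C(=O)N(C)[C@H](C(=O)N1C[C@@H](O)C[C@H]1C(=O)N1C(=O)C=C[C@@H]1C)C(C)C)[C@@H](C)O`: 75 nM
compound 2, `CCCC[C@@H](C)C[C@@H](C)C(=O)N(C)[C@@H](CC(C)C)C(=O)N[C@H](C(=O)N(C)[C@H](C(=O)N1CCC[C@H]1C(=O)N1C(=O)CC[C@@H]1C)C(C)C)[C@@H](C)O`: > 30000 nM

Two compounds share a core here and were tested in a functional assay on NCI-H460 cells (Homo sapiens) for cytotoxicity, read by MTT assay, with a stated time of 48 h; on this read-out higher numbers stand for weaker inhibition and lower numbers for stronger inhibition. Compound 1 gives 75 nM. From the compounds shown here alone, compound 2 is a different case: in this assay compound 2 reaches only the limit > 30000 nM, which is a limit of the assay and not a number, so its true value is unknown. That limit is where compound 2 stands (the limit of > 30000 nM in this assay, at which 1 of the 2 values shown sits).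

The third compound, compound 3, `CCCC[C@@H](C)C[C@@H](C)C(=O)N(C)[C@@H](CC(C)C)C(=O)N[C@H](C(=O)N(C)[C@H](C(=O)N1C[C@@H](O)C[C@H]1C(=O)N1C(=O)CC[C@@H]1C)C(C)C)[C@@H](C)O`, is not yet measured. It differs from compound 2 in one place: hydroxy in place of hydrogen on a saturated ring carbon. The same hydroxy group is also present in compound 1.

Because compound 2 sits at a limit, the step from compound 2 to compound 3 cannot be sized from the numbers; only a direction toward stronger inhibition seems plausible, and the expected step is an at least 3.0-fold lower number from compound 2 to compound 3 (0.47 log units; beyond the scatter). Compound 3 is expected to show roughly 10000 nM in this assay, within a range from 1500 nM to 30000 nM.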

Compound 3, half-maximal inhibitory concentration: 2000 nM
Beside the measured number, compound 3's estimate is 5.0-fold (0.70 log units) above it, within the range that was stated.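

In this assay, this saturated ring carbon proves sensitive to substitution, as hydroxy in place of hydrogen gives an at least 15-fold lower number from compound 2 to compound 3 (1.17 log units; beyond the scatter). The hydroxy group alone does not bring the activity to the level of compound 1, however: a change in the five-membered ring group on a carbonyl carbon, with the heavy-atom count unchanged, gives a 27-fold higher number from compound 1 to compound 3 (1.43 log units; beyond the scatter), so this second site also matters strongly. Compound 2 has only a limit and not a number, which leaves the true size of the hydroxy step unknown: the limit of > 30000 nM in this assay, at which 1 of the 3 values shown sits.

From the compounds shown here alone, it remains open whether a methoxy group or an amino group on the same ring carbon would produce a similar step. Also open, going by these compounds, is how much the hydroxy group contributes when the ring group of compound 1 is present.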